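Hydrogen in place of methoxy on compound 1

This account rests on a few compounds, and the source may have more. Where it says the series, first, only, none or still open, it means among the compounds named here.

In a functional assay on MCF7 cells (Homo sapiens) for cytotoxicity (a lower number here means a stronger inhibitor, a higher number a weaker inhibitor), compound 1 `COc1ccc2nc(NC(=O)CCCCC(=O)NO)sc2c1` gives 5.91 ug/mL. Compound 2 `O=C(CCCCCCC(=O)Nc1nc2ccc([N+](=O)[O-])cc2s1)NO` gives 3.83 ug/mL, within the scatter of compound 1, and compound 3 `COc1ccc2nc(NC(=O)CCCCCCC(=O)NO)sc2c1` gives 1.85 ug/mL. Compound 1 thus carries the highest of the three numbers, though it stands clearly apart only from compound 3.

The next compound is compound 4 `O=C(CCCCC(=O)Nc1nc2ccccc2s1)NO`, and the change is hydrogen in place of methoxy on an aromatic carbon. The chain change gives a 3.2-fold lower number from compound 1 to compound 3 (0.50 log units; beyond the scatter), but compound 4 keeps the chain of compound 1, so that step does not bear on this comparison. The closest evidence is the exchange of nitro for methoxy on an aromatic carbon, which gives a 2.1-fold lower number from compound 2 to compound 3 (0.32 log units; beyond the scatter). That step is modest, it was measured on a different chain, and it does not involve hydrogen. Among the measured compounds shown here, no measured compound carries hydrogen at that carbon, so the direction remains uncertain.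

In this assay, an estimated 1.1-fold higher number from compound 1 to compound 4 (0.04 log units; within the scatter) is expected, a change that stays within the scatter. Compound 4 is expected at about 6.5 ug/mL, with an estimated range of 3 ug/mL to 14 ug/mL.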

Compound 4, half-maximal inhibitory concentration: 4.02 ug/mL
For compound 4 the middle estimate is 1.6-fold (0.21 log units) above the measured one; low and high end bracket the measured number.
By their numbers in this assay, from the lowest: compound 3; then compounds 2, 4 and 1 (each within the scatter of the next).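

In this assay, replacing methoxy with hydrogen on this aromatic carbon gives a 1.5-fold lower number from compound 1 to compound 4 (0.17 log units; within the scatter), so on the chain of compound 1 the methoxy group is not needed to hold the number within the scatter. Among the compounds shown here, the earlier comparison at this carbon covered only nitro and methoxy on the longer chain, with a 2.1-fold lower number from compound 2 to compound 3 (0.32 log units; beyond the scatter), and this is the first pair to show the carbon with hydrogen; among the steps so far, only this one stays within the scatter, while the chain step, a 3.2-fold lower number from compound 1 to compound 3 (0.50 log units; beyond the scatter), lies beyond it. No measurement at hand gives a reason for this outcome.

From the compounds shown here alone, whether hydrogen would also match methoxy on the longer chain of compound 3 remains open, since the hydrogen and methoxy pair is known here only on the chain of compound 1. Also open, going by these compounds, is whether an amine or a carboxylic acid at this aromatic carbon would move the number beyond the scatter, on either chain.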